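The source may report more compounds than this note shows. Statements on the series, on what has been measured and on what is new or still open speak of the compounds shown alone.

In a functional assay on MCF7 cells (Homo sapiens) for cytotoxicity, read by colorimetric assay and MTT assay (a lower number here means a stronger inhibitor, a higher number a weaker inhibitor), compound 1 (`COc1ccc(-c2cc3c(OC)cc(OC)cc3n(CCCC#N)c2=O)cc1`) gives 10000 nM and compound 2 (`COc1ccc(-c2cc3c(OC)cc(OC)cc3n(CC(=O)O)c2=O)cc1`) gives 10000 nM. Among the measured compounds shown here, compound 2 therefore stands level with compound 1, its only measured neighbour so far.

Compound 3 (`COC(=O)CCn1c(=O)c(-c2ccc(OC)cc2)cc2c(OC)cc(OC)cc21`) is the next to be read in this assay. Its difference from compound 2 is (methoxycarbonyl)methyl in place of carboxy on a saturated chain carbon bound to an aromatic nitrogen. In words, this is (methoxycarbonyl)methyl in place of carboxy on a saturated chain carbon bound to an aromatic nitrogen. Cut one bond further out, the same difference reads carboxymethyl to 2-(methoxycarbonyl)ethyl.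

For the measured compounds named here, one measured step bears on this change, at the same place on the shared core: no change at the digits printed from compound 1 to compound 2 (within the scatter). That step showed no size at all, but it is a single step and involves no methoxycarbonyl group, so it is weak evidence. No step beyond the scatter is therefore expected for compound 3, though a modest move toward stronger inhibition cannot be excluded.

The expected step is a 1.1-fold lower number from compound 2 to compound 3 (0.05 log units; within the scatter). For compound 3 the estimated value is 9000 nM, with an expected range of 3000 nM to 15000 nM.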

Compound 3, half-maximal inhibitory concentration: 10000 nM
Estimate against measurement, compound 3: 1.1-fold (0.05 log units) below; the measured number falls inside the stated range.
By their numbers in this assay, from the lowest: compounds 1, 2 and 3 (each within the scatter of the next).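

In this assay, exchanging carboxy for (methoxycarbonyl)methyl on a saturated chain carbon bound to an aromatic nitrogen removes the hydrogen-bond donor counted for carboxy and adds carbon atoms, yet the reading does not move (no change at the digits printed from compound 2 to compound 3 (within the scatter)). The comparison with the nitrile-ended chain reads the same way (no change at the digits printed from compound 1 to compound 3 (within the scatter)), so the methyl ester joins the carboxylic acid and the nitrile as a third chain end with no separable effect, and no listed compound goes against this flat picture. No measurement on hand accounts for this absence of a step.

Going by these compounds, with only these three compounds at this position, it remains open whether any group placed here can shift the number in this cell assay, for instance a primary amine, a primary amide, a hydroxy group or a longer chain ending in one of these. Equally open, on these data alone, is whether the shared core can read lower at all when its methoxy groups or the 4-methoxyphenyl group are replaced, for example by hydroxy or fluorine.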